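Swapping Iodo for Fluoro on the Triazole Phenyl

The source may hold more compounds than are shown below. What is called first, only, known or untested is meant among the compounds shown, and "the series" means these compounds.

Compound 1, `CC(C)n1ncc2c(C(=O)NCc3cn(-c4ccccc4)nn3)cccc21`, in a functional assay on PC-3 cells (Homo sapiens) for inhibition, read by MTT assay, with a stated time of 72 h (on this read-out lower numbers stand for stronger inhibition and higher numbers for weaker inhibition), gives 26000 nM.
Compound 2, `CC(C)n1ncc2c(C(=O)NCc3cn(-c4ccc(I)cc4)nn3)cccc21`, in this assay gives > 40000 nM.

The value for compound 2 is not a number but the limit of this assay, (the limit of > 40000 nM in this assay, at which 1 of the 2 values shown sits). Going by the values given here, the only measured step is an at least 1.5-fold higher number from compound 1 to compound 2 (0.18 log units; that floor lies within the scatter); its floor lies within the usual scatter, so it may be a small weakening or none at all.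

Compound 3 is `CC(C)n1ncc2c(C(=O)NCc3cn(-c4ccc(F)cc4)nn3)cccc21`. It differs from compound 2 in one place: fluoro in place of iodo on an aromatic carbon. Among the compounds with values here, no measured pair shows this exact change, so the expectation rests on compound 1 and compound 2 alone. Compound 1 carries hydrogen at that carbon and compound 2 carries iodo; fluoro is a third substituent there, and the two known points lie close together in this assay.

Compound 3 is therefore expected to sit near those two points, with an expected step of an at least 1.3-fold lower number from compound 2 to compound 3 (0.12 log units; that floor lies within the scatter). The estimate for compound 3 in this assay is 30000 nM, in a range from 12000 nM to 80000 nM, with a real chance that only a limit is reported.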

Compound 3, half-maximal inhibitory concentration: > 40000 nM
Compound 3 ended at the assay's limit; the forecaster's own chance of this, stated with the estimate: 35%; middle value at least 1.3-fold (0.12 log units) away from the limit.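

Compound 3 now sits at the same assay limit as compound 2, so fluoro and iodo cannot be ranked at this carbon and the step between them cannot be read. Measured against hydrogen at the same carbon, fluoro gives an at least 1.5-fold higher number from compound 1 to compound 3 (0.18 log units; that floor lies within the scatter), so, as with iodo, the change may be a small weakening or none at all. What the earlier pair could not show is that reaching the limit is not tied to iodo alone, since two different halogens on this phenyl ring now end there while compound 1, with hydrogen, is the one compound of the three that gives a true number: the limit of > 40000 nM in this assay, at which 2 of the 3 values shown sit.

The compounds shown leave open how far compound 2 and compound 3 actually lie beyond the limit, so any real difference between fluoro and iodo stays hidden. They also leave open whether a group of another kind at this carbon, such as an amine, a carboxylic acid or a methoxy group, would give a number clearly lower than that of compound 1.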